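The compounds below may be only part of what the source reports. "The series", "measured", "known", "first", "only" and "open" are said of these compounds alone.

Measured compounds:
compound 1 `Cc1cc(N(C)Cc2ccccn2)n2nc(C)c(-c3ccccc3)c2n1` — 17500 nM
compound 2 `COc1ccc(-c2c(C)nn3c(NCc4ccccn4)cc(C)nc23)cc1` — < 5000 nM
compound 3 `Cc1cc(NCc2ccccn2)n2ncc(-c3cccc(F)c3)c2n1` — 5000 nM

Of the compounds shown here, three sharing one core have been tested in a physicochemical assay for solubility, read by HPLC, using the shake flask method, measured as kinetic solubility, with a stated time of 2 h, at pH 7.4; on this read-out lower numbers stand for lower solubility and higher numbers for higher solubility. Compound 1 gives 17500 nM in this assay. For compound 2 this assay returns only a limit, < 5000 nM, and not a number. Compound 3 gives 5000 nM, the lower of the two numbers; compound 1 stands higher than compound 3, and that gap lies beyond the usual scatter of this assay. One further value, that of compound 2, is a limit, as described by the limit of < 5000 nM in this assay, at which 1 of the 3 values shown sits.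

Compound 4 `Cc1cc(NCc2ccccn2)n2ncc(-c3ccc(O)cc3)c2n1` has not yet been measured in this assay. It differs from compound 3 in one place: 4-hydroxyphenyl in place of 3-fluorophenyl on an aromatic carbon. For the measured compounds named here, no pair of measured compounds differs in a single place, so no measured step can be set beside this change. Going by the values given here, the expectation for this change from compound 3 to compound 4 is a modest rise in solubility, a 1.8-fold higher number from compound 3 to compound 4 (0.26 log units; within the scatter), though the data at hand give no measured step of this kind to rest it on. For compound 4 the estimated solubility in this assay is 9000 nM, expected to fall between 3000 nM and 25000 nM.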

Compound 4, solubility: 10900 nM
Compound 4: middle estimate off by 1.2-fold (0.08 log units), on the low side, and the stated range covers the measured number.
By their numbers in this assay, from the lowest: compound 3; then compounds 4 and 1 (each within the scatter of the next).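

In this assay, for the compounds shown here, the change to 4-hydroxyphenyl in place of 3-fluorophenyl, on an aromatic carbon of a five-membered aromatic ring with 2 nitrogen, gives a 2.2-fold higher number from compound 3 to compound 4 (0.34 log units; beyond the scatter), and this is the first step that differs in a single place. It shows that the number in this assay moves beyond the usual scatter when only the aryl group at this position is exchanged, while the rest of the shared core stays the same, though the step is modest in size and the exchange replaces fluorine with oxygen and also moves the substituent to a different ring carbon. Nothing measured here accounts for the size or direction of this step.

On these data alone, it remains open how much of the step belongs to the change of atom and how much to the change of ring carbon, and whether the same exchange would give a similar step on the core of compound 1. As far as these compounds go, it is also open what an amine or a carboxylic acid would do on this phenyl ring in place of the hydroxyl group.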